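Shifting the Methoxy Groups on a Dimethoxyphenyl Ring

A few compounds are considered here, and "the series" means these few. Any claim that something is new, unique, unknown or untested is made for them only; others in the source may bear on it.

Among the measured compounds shown here, in a functional assay on A549 cells (Homo sapiens) for inhibition, read by MTT assay, with a stated time of 48 h (on this read-out higher numbers stand for weaker inhibition and lower numbers for stronger inhibition), compound 1 `Oc1ccc(C(c2c[nH]c3ccc(Br)cc23)c2c[nH]c3ccc(Br)cc23)cc1` gives 9000 nM and compound 2 `COc1ccc(C(c2c[nH]c3ccc(Br)cc23)c2c[nH]c3ccc(Br)cc23)cc1OC` gives 12000 nM, so compound 2 stands within the scatter of the only other measured value. Compound 3 `COc1ccc(OC)c(C(c2c[nH]c3ccc(Br)cc23)c2c[nH]c3ccc(Br)cc23)c1` has 2,5-dimethoxyphenyl in place of 3,4-dimethoxyphenyl on a saturated chain carbon bound to two aromatic carbons. For the measured compounds named here, the one measured step, a 1.3-fold higher number from compound 1 to compound 2 (0.12 log units; within the scatter), lies within the scatter and involves a different change, so no step beyond the scatter is expected in this assay. The expected change is a 1.1-fold lower number from compound 2 to compound 3 (0.04 log units; within the scatter). For compound 3 the estimated value is 11000 nM, with an expected range of 5000 nM to 25000 nM.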

Compound 3, half-maximal inhibitory concentration: 10000 nM
Beside the measured number, compound 3's estimate is 1.1-fold (0.04 log units) above it; the range from low to high includes it.
By their numbers in this assay, from the lowest: compounds 1, 3 and 2 (each within the scatter of the next).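

In this assay, moving the methoxy groups from 3,4-dimethoxyphenyl to 2,5-dimethoxyphenyl gives a 1.2-fold lower number from compound 2 to compound 3 (0.08 log units; within the scatter) and so leaves the two arrangements indistinguishable on a saturated chain carbon bound to two aromatic carbons. Replacing 4-hydroxyphenyl with 2,5-dimethoxyphenyl gives a 1.1-fold higher number from compound 1 to compound 3 (0.05 log units; within the scatter) and so also makes no readable difference, which means all three groups read alike at this position. No available evidence accounts for this sameness.

Still open, from the compounds shown here alone, is whether a different group on this ring, such as an amine or a carboxylic acid, would give a step beyond the scatter.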